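The source may report more compounds than this note shows. Statements on the series, on what has been measured and on what is new or still open speak of the compounds shown alone.

Compound 1 `CN(OCCO)C(=O)c1n[nH]c2c1CN(C(=O)Nc1cccc(Cl)c1)CC2` gives 31 mL/min/kg in an ADME assay on microsomes from liver (Homo sapiens) for metabolic stability (a higher number here means faster removal of the compound, a lower number slower removal), the lower of the two numbers in hand. Compound 2 `O=C(Nc1cccc(Cl)c1)N1CCc2[nH]nc(-c3ccccc3)c2C1` gives 192 mL/min/kg in this assay, and the step of a 6.2-fold higher number from compound 1 to compound 2 (0.79 log units; beyond the scatter) shows that a change of the group on that aromatic carbon can move the number well beyond the scatter. Compound 3 `CN(OC1COC1)C(=O)c1n[nH]c2c1CN(C(=O)Nc1cccc(Cl)c1)CC2` differs from compound 1 on an oxygen whose other neighbour is an amide-type nitrogen: oxetan-3-yl in place of 2-hydroxyethyl on an oxygen. Among the compounds with values here, no measured step puts oxetan-3-yl in place of 2-hydroxyethyl on an oxygen, so the only step available, which swaps the whole (2-hydroxyethoxy)(methyl)carbamoyl group for phenyl, bears on this smaller change only loosely. The number for compound 3 is expected to stay close to that of compound 1, with a 1.4-fold higher number from compound 1 to compound 3 (0.13 log units; within the scatter) expected to fall within or just beyond the scatter. Compound 3 is therefore estimated at 42 mL/min/kg in this assay, with a range of 20 mL/min/kg to 85 mL/min/kg.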

Compound 3, clearance in the Homo sapiens assay: 8 mL/min/kg
The estimate for compound 3 lay 5.3-fold (0.72 log units) above the measured number; measured number outside the range, below it.
By their numbers in the Homo sapiens assay, from the lowest: compound 3; then compound 1; then compound 2.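

Even this small change on an oxygen whose other neighbour is an amide-type nitrogen moves the number in the Homo sapiens assay beyond the scatter, with a 3.9-fold lower number from compound 1 to compound 3 (0.59 log units; beyond the scatter), so the outer end of the group matters and not only the whole group seen in the earlier step. With the full methyl((oxetan-3-yl)oxy)carbamoyl group in place of phenyl on the aromatic carbon, the gap widens to a 24-fold lower number from compound 2 to compound 3 (1.38 log units; beyond the scatter). In a physicochemical assay for solubility, measured as thermodynamic solubility, at pH 7 (on this read-out higher numbers stand for higher solubility and lower numbers for lower solubility), compound 1 gives 161000 nM and compound 3 gives 183000 nM, and a 1.1-fold higher number from compound 1 to compound 3 (0.06 log units; within the scatter) leaves the two within the scatter of each other.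

Nothing in hand accounts for the lower number in compound 3. Open, from the compounds shown here alone, is whether the ring itself or the loss of the hydroxyl group carries the step, which a plain methyl, a cyclobutyl ring or a longer ether chain on that oxygen could separate.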